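The compounds below may be only part of what the source reports. "The series", "measured", "known", "first", "only" and "open" are said of these compounds alone.

Measured compounds in an assay for inhibition of ATP-dependent RNA helicase DDX3X (Homo sapiens), read by FRET, with a stated time of 40 min, in the presence of a further agent that is not named here; a higher number here means a weaker inhibitor, a lower number a stronger inhibitor:
- compound 1 `CCCCc1cn(-c2ccc(NC(=O)Nc3ccccc3C)cc2)nn1`: 300 nM
- compound 2 `CCCCc1cn(-c2cccc(S(=O)(=O)Nc3ccccc3C(F)(F)F)c2)nn1`: 400 nM
- compound 3 `CCCCc1cn(-c2cccc(S(=O)(=O)Nc3cccc4cnccc34)c2)nn1`: 120 nM

Compound 2 has the highest number of the three. Its value and that of compound 1 lie within the scatter, so nothing can be said about their order. Compound 3 gives a clearly lower number than compound 2, a gap beyond the scatter.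

Compound 4 `CCCCc1cn(-c2cccc(S(=O)(=O)Nc3ccccc3OC)c2)nn1` is not yet measured. Going by the values given here, it differs from compound 2 by methoxy in place of trifluoromethyl on an aromatic carbon; no measured pair shows this change, so no step size is known for it. Compound 4 is expected to give a number close to that of compound 2, with the step of no change at the digits printed from compound 2 to compound 4 (within the scatter) expected to be none beyond the scatter. The estimate for compound 4 is 400 nM, with a range from 150 nM to 1100 nM.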

Compound 4, half-maximal inhibitory concentration: 180 nM
The estimate for compound 4 lay 2.2-fold (0.35 log units) above the measured number; the range from low to high includes it.
By their numbers in this assay, from the lowest: compounds 3, 4, 1 and 2 (each within the scatter of the next, the first and the last beyond it).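

In this assay, going by these compounds alone, the aromatic carbon ortho to a large group responds to a change of substituent: methoxy in place of trifluoromethyl gives a 2.2-fold lower number from compound 2 to compound 4 (0.35 log units; beyond the scatter), the first single-place step. Trifluoromethyl is therefore not required at this carbon, and a group with fewer heavy atoms and one hydrogen-bond acceptor is accepted. No measurement shown explains this step.

On these data alone, whether the step follows the oxygen or the lower heavy-atom count remains open. Methyl, ethoxy or hydroxyl on the same carbon would help separate these two readings.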